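Working notes: replacing the 2,6-dimethylphenyl group of compound 2

The source may hold more compounds than are shown below. What is called first, only, known or untested is meant among the compounds shown, and "the series" means these compounds.

Readings so far in a functional assay on MDA-MB-231 cells (Homo sapiens) for antiproliferative activity, read by MTT assay, with a stated time of 72 h (on this read-out lower numbers stand for stronger inhibition and higher numbers for weaker inhibition), for two compounds:
- compound 1 (`O=C(O)/C=C/c1ccc(-c2ccc(F)cc2)c(Cl)c1`) gives > 100000 nM (a limit)
- compound 2 (`Cc1cccc(C)c1-c1cc(-c2ccc(/C=C/C(=O)O)cc2Cl)ccc1O`) gives > 10000 nM (a limit)

Compound 2 has no numerical reading, only the limit > 10000 nM as its result. The two limits set no order between compound 1 and compound 2.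

The next compound is compound 3 (`CCC(CC)(CC)c1cc(-c2ccc(/C=C/C(=O)O)cc2Cl)ccc1O`). It differs from compound 2 by a single exchange (1,1-diethylpropyl in place of 2,6-dimethylphenyl on an aromatic carbon), with 1,1-diethylpropyl in place of 2,6-dimethylphenyl on an aromatic carbon, ortho to a hydroxy group and meta to a large group.

Within the data shown here, no measured pair shows what this exchange does, so the expectation is a judgement. The estimated at least 3.3-fold lower number from compound 2 to compound 3 (0.52 log units; beyond the scatter) points to stronger inhibition beyond the scatter, but it starts from a limit and its size is uncertain. Another limit for the new compound also remains possible. In this assay compound 3 is expected at 3000 nM with an estimated range from 400 nM to 15000 nM as the working figure.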

Compound 3, half-maximal inhibitory concentration: > 5000 nM
Compound 3 was reported as a limit (the forecaster's own chance of this, stated with the estimate: 30%); middle value at least 1.6-fold (0.22 log units) from the limit.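

In this assay compound 3 gives > 5000 nM, which is a limit. Among these compounds, compound 2 also has only a limit, and no step between compound 2 and compound 3 can be read. The compounds shown leave open how 1,1-diethylpropyl and 2,6-dimethylphenyl compare in this assay, and whether either compound reaches a numerical reading.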